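Changing the Amide Substituent on the Shared Core

The compounds below may be only part of what the source reports. "The series", "measured", "known", "first", "only" and "open" are said of these compounds alone.

The measured compounds are:
compound 1, `C=CCN(C)C(=O)c1ccc(C(CC)(CC)c2ccc(OCCC(O)(CC)CC)c(C)c2)n1CC`, with 1190 nM in an ADME assay on L02 cells (Homo sapiens) for antiproliferative activity, read by MTT assay, with a stated time of 48 h; a lower number here means a stronger inhibitor, a higher number a weaker inhibitor;
compound 2, `CCn1c(C(=O)Nc2ccc(OC(F)(F)F)cc2)ccc1C(CC)(CC)c1ccc(OCCC(O)(CC)CC)c(C)c1`, for which this assay reports only the limit > 50000 nM;
compound 3, `CCn1c(C(=O)N(C)CC(=O)O)ccc1C(CC)(CC)c1ccc(OCCC(O)(CC)CC)c(C)c1`, with 2150 nM.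

Among the two numbers that are not limits, compound 1 gives the lower one, and compound 3 sits nearest to it: the step of a 1.8-fold higher number from compound 1 to compound 3 (0.26 log units; within the scatter) lies within the scatter, so the two are not distinguished. The value of compound 2 is a limit of the assay (the limit of > 50000 nM in this assay, at which 1 of the 3 values shown sits), and the step of an at least 42-fold higher number from compound 1 to compound 2 (1.62 log units; beyond the scatter) is therefore at least large.

Compound 4, `CCC(C)C(CO)NC(=O)c1ccc(C(CC)(CC)c2ccc(OCCC(O)(CC)CC)c(C)c2)n1CC`, differs from compound 1 in one place: (1-(hydroxymethyl)-2-methylbutyl)amino in place of allyl(methyl)amino on a carbonyl carbon. For the measured compounds named here, two measured steps bear on this position. The small step of a 1.8-fold higher number from compound 1 to compound 3 (0.26 log units; within the scatter) shows that a polar substituent on the amide nitrogen is tolerated, while the large step of an at least 42-fold higher number from compound 1 to compound 2 (1.62 log units; beyond the scatter) shows that a secondary amide carrying a lipophilic aryl group is not. Compound 4 combines a secondary amide with a polar aliphatic group, so a moderate rise, a 2.9-fold higher number from compound 1 to compound 4 (0.47 log units; beyond the scatter), is expected. For compound 4 the estimate in this assay is 3500 nM, expected to lie between 1000 nM and 20000 nM.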

Compound 4, half-maximal inhibitory concentration: > 50000 nM
Compound 4: a limit, no number; the forecaster's own chance of this, stated with the estimate: 15%; middle value at least 14-fold (1.15 log units) from the limit.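

In this assay compound 4 gives only a limit and no number: the limit of > 50000 nM in this assay, at which 2 of the 4 values shown sit. The step of an at least 42-fold higher number from compound 1 to compound 4 (1.62 log units; beyond the scatter) and the step of an at least 23-fold higher number from compound 3 to compound 4 (1.36 log units; beyond the scatter) are both large, which shows that on this carbonyl carbon the limit is also reached with the aliphatic (1-(hydroxymethyl)-2-methylbutyl)amino group, so an aryl group as in compound 2 is not needed for it. Among the four compounds, the two amides that keep the amide hydrogen, compound 2 and compound 4, both stand at the limit, so the step between them cannot be read, while the two with a methyl on the amide nitrogen, compound 1 and compound 3, give numbers.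

The compounds shown leave open whether the amide hydrogen or the branched chain goes with the limit. A (1-(hydroxymethyl)-2-methylbutyl)(methyl)amino group or a plain methylamino group on this carbonyl carbon would separate the two.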